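The compounds below may be only part of what the source reports. "The series", "measured", "known", "first", "only" and "open" are said of these compounds alone.

Series of enones on a shared core. In an ADME assay on L929 cells (Mus musculus) for cytotoxicity, read by resazurin assay, with a stated time of 72 h (on this read-out higher numbers stand for weaker inhibition and lower numbers for stronger inhibition), compound 1 `COc1ccccc1C(=O)/C=C/c1ccc2c(c1)B(O)OC2` gives 6.35 ug/mL. For compound 2 `O=C(/C=C/c1ccc2c(c1)B(O)OC2)c1ccco1` the read-out is only a limit, > 10 ug/mL. Compound 3 `COc1cccc(C(=O)/C=C/c2ccc3c(c2)B(O)OC3)c1` likewise returns only a limit, > 10 ug/mL. Compound 2 thus stands at the limit of > 10 ug/mL in this assay, at which 2 of the 3 values shown sit, and compound 1 alone returns a number. Compound 4 `O=C(/C=C/c1ccc2c(c1)B(O)OC2)c1ccc(F)cc1` is not yet measured in this assay; it differs from compound 2 by 4-fluorophenyl in place of furan-2-yl on a carbonyl carbon. Among the measured compounds shown here, no measured pair in this set differs in one place, so no step is on record to anchor an expectation. The expected step is an at least 1.1-fold lower number from compound 2 to compound 4 (0.04 log units; that floor lies within the scatter), within the scatter or none at all. Compound 4 is expected to give 9 ug/mL, with a range of 4 ug/mL to 20 ug/mL, most likely again reported only as a limit.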

Compound 4, half-maximal inhibitory concentration: > 10 ug/mL
Compound 4 ended at the assay's limit; the forecaster's own chance of this, stated with the estimate: 60%; at least 1.1-fold (0.04 log units) between middle value and limit.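

Compound 2 and compound 4 both return only limits in this assay, so no step can be read for 4-fluorophenyl in place of furan-2-yl. The compounds shown leave open both the direction and the size of that replacement's effect.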